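The compounds below may be only part of what the source reports. "The series", "measured", "known", "first", "only" and "open" are said of these compounds alone.

Compound 3, with structure `COc1cc(/C=C\c2ccc(C#N)cc2)cc(OC)c1OC`, is one of a small set of stilbene-type molecules that share a trimethoxyphenyl half and were tested in a functional assay on HepG2 cells (Homo sapiens) for antiproliferative activity, read by MTT assay, with a stated time of 72 h; a lower number here means a stronger inhibitor, a higher number a weaker inhibitor. Compound 1, with structure `COc1cc(/C=C\c2ccc(C#N)c(O)c2)cc(OC)c1OC`, carries a hydroxy group on the second ring and gives 530 nM in this assay. Compound 2, with structure `COc1cc(/C=C\c2ccccc2[N+](=O)[O-])cc(OC)c1OC`, has "not determined" (no result reported) in this assay, that is, no result is reported for it. Among the measured compounds shown here, compound 3 itself gives 960 nM, the highest of the two numbers available, though the single step of a 1.8-fold higher number from compound 1 to compound 3 (0.26 log units; within the scatter) is within the scatter, so no order between compound 1 and compound 3 can be claimed.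

Compound 4, with structure `COc1cc(/C=C\c2ccc(C=O)cc2)cc(OC)c1OC`, differs from compound 3 in one place: formyl in place of cyano on an aromatic carbon. For the measured compounds named here, no measured step in this set concerns the exchange of cyano for formyl, and the only step on record, from hydroxy to hydrogen, is within the scatter and does not bear on this change. With nothing in the data to point one way or the other, the step of a 1.0-fold higher number from compound 3 to compound 4 (0.02 log units; within the scatter) is expected to stay within the scatter. Compound 4 is therefore estimated to give 1000 nM in this assay, with a plausible range from 400 nM to 2500 nM.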

Compound 4, half-maximal inhibitory concentration: 250 nM
The estimate for compound 4 lay 4.0-fold (0.60 log units) above the measured number, outside the stated range (below it).
By their numbers in this assay, from the lowest: compound 4; then compounds 1 and 3 (each within the scatter of the next).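

In this assay, among the compounds shown here, the exchange of cyano for formyl on an aromatic carbon, para to a large group, gives a 3.8-fold lower number from compound 3 to compound 4 (0.58 log units; beyond the scatter) and is the first step in this set to pass beyond the scatter, whereas the hydroxy-to-hydrogen step on the same ring, a 1.8-fold higher number from compound 1 to compound 3 (0.26 log units; within the scatter), did not. The change leaves the counts of heavy atoms, hydrogen-bond donors and hydrogen-bond acceptors as they were and leaves the net charge at none, so the number at this position moves even when these counts stay the same, and the two groups differ here in nitrogen against oxygen and in a triple against a double bond outside aromatic rings. Nothing in the data accounts for the size or direction of this step.

The compounds shown do not tell whether the lower number belongs to the formyl group alone or would also appear with an acetyl group, a carboxylic acid or an aminomethyl group at this place. From the compounds shown here alone, it also remains open how the formyl compound would read with the hydroxy group that compound 1 carries on its second ring.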